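Working notes: the step from compound 3 to compound 4

The source may hold more compounds than are shown below. What is called first, only, known or untested is meant among the compounds shown, and "the series" means these compounds.

compound 1: `CCNCCCCNCCCN`, 40000 nM
compound 2: `CCNCCCCNCCCCNCC`, 350 nM
compound 3: `CCNCCCCCNCCCCNCC`, 200 nM
compound 4: `CCNCCCCCNCCCCCNCC`, not yet measured

In a functional assay on L1210 cells (Mus musculus) for inhibition, with a stated time of 96 h (a lower number here means a stronger inhibitor, a higher number a weaker inhibitor), compound 3 gives 200 nM, and compound 2 gives 350 nM, so the two cannot be separated, while compound 1 stands far off. The change to compound 4 is (ethylamino)methyl in place of ethylamino on a saturated chain carbon, four bonds along the chain from an amine nitrogen.

Among the measured compounds shown here, the closest precedent is the same replacement, read in the same words, in a 1.8-fold lower number from compound 2 to compound 3 (0.24 log units; within the scatter). The two large steps, a 110-fold lower number from compound 1 to compound 2 (2.06 log units; beyond the scatter) and a 200-fold lower number from compound 1 to compound 3 (2.30 log units; beyond the scatter), both replace amino, a group that compound 3 does not carry, so they bear on this change only weakly. One precedent is thin support, but it points to no move beyond the scatter. The expected step is a 1.1-fold higher number from compound 3 to compound 4 (0.04 log units; within the scatter). Compound 4 is estimated at 220 nM, with an expected range of 70 nM to 650 nM.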

Compound 4, half-maximal inhibitory concentration: 700 nM
Estimate against measurement, compound 4: 3.2-fold (0.50 log units) below; measured number above the stated range.
By their numbers in this assay, from the lowest: compounds 3, 2 and 4 (each within the scatter of the next, the first and the last beyond it); then compound 1.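

In this assay the replacement of ethylamino by (ethylamino)methyl on a saturated chain carbon, four bonds along the chain from an amine nitrogen, gives a 3.5-fold higher number from compound 3 to compound 4 (0.54 log units; beyond the scatter) and so passes beyond the scatter, while the same replacement in a 1.8-fold lower number from compound 2 to compound 3 (0.24 log units; within the scatter) stayed within it. This change therefore has no fixed outcome in the series: read in the same words, it moves the number beyond the scatter when made on compound 3 but not when made on compound 2. Nothing available bears on why the two readings differ.

Two steps cannot show whether a longer chain at this place would carry the number further up in this assay or leave it within the scatter. As far as these compounds go, the effect of a propylamino or methylamino group in place of the ethylamino ends also remains open.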